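One more chain carbon before the hydroxycarbamoyl group

This account rests on a few compounds, and the source may have more. Where it says the series, first, only, none or still open, it means among the compounds named here.

Measured in an assay for binding affinity to histone acetyltransferase KAT2B (Homo sapiens), tested at 25 uM; a higher number here means that the compound stabilises the target more against heat, a lower number that the compound stabilises the target less:
compound 1, `Cc1noc(C)c1-c1cc(OCCCCC(=O)NO)cc(C(=O)c2ccccc2)c1`, gives -7.9 degrees C
compound 2, `Cc1noc(C)c1-c1cc(OCCCCCC(=O)NO)cc(C(=O)c2ccccc2)c1`, gives 0.28 degrees C

Of the two numbers, compound 2 holds the higher one. Among the measured compounds shown here, the single step that separates the pair, a number 8.2 degrees C higher from compound 1 to compound 2 (beyond the scatter), was large and well beyond the scatter, and it came from the same kind of change that is now being repeated: the chain between the aromatic oxygen and the hydroxycarbamoyl group was lengthened by one carbon.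

Compound 3, `Cc1noc(C)c1-c1cc(OCCCCCCC(=O)NO)cc(C(=O)c2ccccc2)c1`, repeats that move one bond further out: (hydroxycarbamoyl)methyl in place of hydroxycarbamoyl on a saturated chain carbon, five bonds along the chain from an oxygen on an aromatic ring.

For the measured compounds named here, only that one earlier step bears on this change, and it points upward. Yet nothing shows whether a second lengthening keeps helping, does nothing, or reverses; a single step gives no trend. The expectation is therefore cautious: a step of a number 0.72 degrees C higher from compound 2 to compound 3 (within the scatter) in this assay is estimated, which is not beyond the scatter. For compound 3 the expected value is 1 degrees C, with a range from -4 degrees C to 5 degrees C.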

Compound 3, shift of the target's melting temperature: 1.04 degrees C
For compound 3 the middle estimate is 0.040 degrees C below the measured one, within the range that was stated.
By their numbers in this assay, from the lowest: compound 1; then compounds 2 and 3 (each within the scatter of the next).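

In this assay, adding a second chain carbon does not repeat the large effect of the first, giving a number 0.76 degrees C higher from compound 2 to compound 3 (within the scatter) so that compounds 2 and 3 cannot be told apart at this position. Taken together, the two lengthenings amount to a number 8.9 degrees C higher from compound 1 to compound 3 (beyond the scatter) and this leaves compound 1 as the only one of the three that stands clearly apart, so the read-out does not climb evenly with each added carbon but shows one large step and then no step that can be read. Nothing measured here explains why one added carbon matters so much and the next shows no clear effect.

A longer chain could stay level with compounds 2 and 3 or could bring the number down again, and the three chain lengths shown cannot tell which. Also open, on these data alone, is what a carboxylic acid or an amine would give in place of the hydroxycarbamoyl group at the end of the chain of compound 3, which would show how much the read-out depends on that end group rather than on chain length alone.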